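A Second Halogen on the Sulfonamide Aryl Group

The source may report more compounds than this note shows. Statements on the series, on what has been measured and on what is new or still open speak of the compounds shown alone.

Of the compounds shown here, three sharing one core have been measured in an assay on HEK293 cells for inhibition of solute carrier family 22 member 12 (Homo sapiens); on this read-out lower numbers stand for stronger inhibition and higher numbers for weaker inhibition. Compound 1 `O=C(CSc1nnc(Br)n1Cc1ccc(Br)c2ccccc12)NO` gives 640 nM. Compound 2 `O=S(=O)(CSc1nnc(Br)n1Cc1ccc(Br)c2ccccc12)Nc1ccccc1` gives 15800 nM, and the step of a 25-fold higher number from compound 1 to compound 2 (1.39 log units; beyond the scatter) is the largest seen in this set. Compound 3 `O=S(=O)(CSc1nnc(Br)n1Cc1ccc(Br)c2ccccc12)Nc1ccc(Cl)nc1` gives 1940 nM; the step of an 8.1-fold lower number from compound 2 to compound 3 (0.91 log units; beyond the scatter) recovers much of that loss. Compound 3 therefore stands second highest of the three numbers, with compound 1 lower and compound 2 higher, both gaps beyond the scatter.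

Compound 4 `O=S(=O)(CSc1nnc(Br)n1Cc1ccc(Br)c2ccccc12)Nc1ccc(Br)nc1Br` differs from compound 3 by 2,6-dibromopyridin-3-yl in place of 6-chloropyridin-3-yl on a sulfonamide nitrogen. Among the compounds with values here, no measured pair shows this exact exchange. Within the data shown here, the only step that bears on it is an 8.1-fold lower number from compound 2 to compound 3 (0.91 log units; beyond the scatter), which shows that the group on the sulfonamide nitrogen can move the number by a modest amount; the step of a 25-fold higher number from compound 1 to compound 2 (1.39 log units; beyond the scatter) concerns a different position and gives no direction here. Without a matched pair, the writer expects compound 4 to stay close to compound 3, with the step of a 1.5-fold lower number from compound 3 to compound 4 (0.17 log units; within the scatter) regarded as uncertain in sign and most likely within or near the scatter. The estimate for compound 4 in this assay is 1300 nM, with a range from 350 nM to 5000 nM.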

Compound 4, half-maximal inhibitory concentration: 5410 nM
The estimate for compound 4 lay 4.2-fold (0.62 log units) below the measured number; the measured number lies above the stated range.
By their numbers in this assay, from the lowest: compound 1; then compound 3; then compound 4; then compound 2.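

In this assay, the exchange on the sulfonamide nitrogen does not extend the gain seen earlier with 6-chloropyridin-3-yl: 2,6-dibromopyridin-3-yl gives a 2.8-fold higher number from compound 3 to compound 4 (0.45 log units; beyond the scatter), so adding halogen atoms to the pyridine ring does not by itself lower the number. Yet the dibromo group keeps part of the advantage over phenyl, with a 2.9-fold lower number from compound 2 to compound 4 (0.47 log units; beyond the scatter), which places both halogenated pyridines on the lower side of the plain phenyl compound, while neither reaches compound 1 at 640 nM. No measurement here bears on the cause of this reversal.

The step changes the kind and the number of halogen atoms together, so the compounds shown cannot tell whether bromine in place of chlorine or the extra substituent accounts for the rise. A pyridin-3-yl group carrying a single bromine or two chlorines would separate these two changes, and one carrying an amine or a methoxy group would show whether this position responds to anything other than halogen.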